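A few compounds are considered here, and "the series" means these few. Any claim that something is new, unique, unknown or untested is made for them only; others in the source may bear on it.

Measured in a functional assay on A-427 cells (Homo sapiens) for cytotoxicity, read by colorimetric assay and MTT assay; a lower number here means a stronger inhibitor, a higher number a weaker inhibitor:
- compound 1 `COc1ccc(-c2cc3c(OC)cc(OC)cc3n(CC(=O)OCc3ccccc3)c2=O)cc1`: 10000 nM
- compound 2 `COc1ccc(-c2cc3c(OC)cc(OC)cc3n(CC(=O)O)c2=O)cc1`: 10000 nM

For the measured compounds named here, compound 2 stands level with its only measured neighbour: compound 1 reads the same, and compound 2 gives 10000 nM. The next compound, compound 3 `COC(=O)CCn1c(=O)c(-c2ccc(OC)cc2)cc2c(OC)cc(OC)cc21`, differs from compound 2 as follows: (methoxycarbonyl)methyl in place of carboxy on a saturated chain carbon bound to an aromatic nitrogen. In words, (methoxycarbonyl)methyl takes the place of carboxy on a saturated chain carbon bound to an aromatic nitrogen.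

Going by the values given here, only one measured step bears on this change, no change at the digits printed from compound 1 to compound 2 (within the scatter), where hydrogen replaces benzyl on an oxygen. That step lies within the scatter, so the swap between a free carboxy and an ester left the reading unmoved in this assay. Among the compounds with values here, no measured compound tests the longer chain. No step beyond the scatter is therefore expected, and the expected step is no change at the digits printed from compound 2 to compound 3 (within the scatter). Compound 3 is estimated at 10000 nM, with an expected range of 3000 nM to 20000 nM.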

Compound 3, half-maximal inhibitory concentration: 10000 nM
Estimate against measurement, compound 3: no gap at the digits printed, within the range that was stated.
By their numbers in this assay, from the lowest: compounds 1, 2 and 3 (each within the scatter of the next).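

The chain on the aromatic nitrogen now varies as well as its end group: in this assay, replacing carboxymethyl with 2-(methoxycarbonyl)ethyl gives no change at the digits printed from compound 2 to compound 3 (within the scatter), and the comparison with the benzyl ester gives no change at the digits printed from compound 1 to compound 3 (within the scatter). Across the free carboxy group and both esters, therefore, no change at this place has yet moved the reading beyond the scatter. No supporting evidence bears on this result.

As far as these compounds go, it remains open whether an amine or an amide at the end of the chain, or a free carboxylic acid on the longer chain, would separate from these three compounds. The shared core also stays constant throughout, so replacing its methoxy groups with hydroxy or fluoro remains an open question.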